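Shortening the Side Chain of Compound 1

The compounds below may be only part of what the source reports. "The series", "measured", "known", "first", "only" and "open" are said of these compounds alone.

Of the compounds shown here, three sharing one core have been tested in a functional assay on SK-OV-3 cells (Homo sapiens) for cytotoxicity, read by MTT assay, with a stated time of 48 h; on this read-out lower numbers stand for stronger inhibition and higher numbers for weaker inhibition. Compound 1 `CCCCCCOc1ccc2c(Cl)ccnc2c1` carries a chlorine and a hexyl chain bound to an oxygen on the aromatic ring. In this assay, within the data shown here, compound 1 gives > 10000 nM, which is a limit of the assay rather than a number; compound 1 is the one value among the three that sits at the limit of > 10000 nM in this assay, at which 1 of the 3 values shown sits. Compound 2 `CCOc1ccc2c(NCCCN(C)C)ccnc2c1` and compound 3 `CN(C)CCCNc1ccnc2cc(OCc3ccc(F)cc3)ccc12` replace the chlorine with a chain bearing an amine; compound 2 gives 6780 nM and compound 3 gives 1280 nM. Among the measured compounds shown here, the one measured step, a 5.3-fold lower number from compound 2 to compound 3 (0.72 log units; beyond the scatter), concerns the group on the chain carbon bound to the ring oxygen in the amine-bearing pair, not the chlorine-bearing series.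

Compound 4 `CCCCOc1ccc2c(Cl)ccnc2c1` differs from compound 1 by hydrogen in place of ethyl on a saturated chain carbon, four bonds along the chain from an oxygen on an aromatic ring. For the measured compounds named here, no measured step covers this change; compound 1 stands at the limit, and compounds 2 and 3 differ from it in a second place as well. For compound 4 the expected step is therefore a step that the limit leaves unreadable from compound 1 to compound 4, nothing beyond the scatter. The estimate for compound 4 in this assay is 15000 nM, with a range from 5000 nM to 50000 nM, and most likely the assay again reports only its limit.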

Compound 4, half-maximal inhibitory concentration: 4130 nM
Beside the measured number, compound 4's estimate is 3.6-fold (0.56 log units) above it; the measured number lies below the stated range.
By their numbers in this assay, from the lowest: compound 3; then compounds 4 and 2 (each within the scatter of the next). At a limit, above all of these: compound 1.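

Compound 4 gives the chlorine-bearing series its first actual number in this assay, and so shows that the chain on the ring oxygen counts in this series: hydrogen in place of ethyl, on a saturated chain carbon four bonds along the chain from an oxygen on an aromatic ring, gives an at least 2.4-fold lower number from compound 1 to compound 4 (0.38 log units; beyond the scatter). A larger group on that oxygen therefore does not act in a single direction across the compounds shown, since here the smaller chain goes with the lower number, while the amine-bearing pair, which goes against this, shows a 5.3-fold lower number from compound 2 to compound 3 (0.72 log units; beyond the scatter). The step from the longer chain has no known upper size, because the value at its start is only a limit of the assay: the limit of > 10000 nM in this assay, at which 1 of the 4 values shown sits.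

On these data alone, whether the number keeps falling as the chain gets shorter still, with a propyl or an ethyl chain on the oxygen and the chlorine kept, remains open. Also open, as far as these compounds go, is how the same chain shortening would read with an amine-bearing chain in place of the chlorine, or with a carboxylic acid at the end of the chain on the oxygen.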